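This account rests on a few compounds, and the source may have more. Where it says the series, first, only, none or still open, it means among the compounds named here.

Of the compounds shown here, two of a shared core have been measured in a functional assay on L132 cells (Homo sapiens) for cytotoxicity, read by MTT assay, with a stated time of 72 h; on this read-out lower numbers stand for an effect already at smaller amounts and higher numbers for an effect only at larger amounts of compound. Compound 1 `O=C1/C(=C\c2cccc(Oc3ccccc3)c2)c2ccccc2N1c1c(Cl)cccc1Cl` gives 24 ug/mL. Compound 2 `O=C1/C(=C\c2ccc(F)cc2)c2ccccc2N1c1c(Cl)cccc1Cl` gives 13 ug/mL, and the gap between compound 2 and compound 1 lies within the usual scatter, so the two cannot be told apart. Compound 3 `O=C1/C(=C\c2ccc(O)cc2)c2ccccc2N1c1c(Cl)cccc1Cl` has not been measured; it differs from compound 2 by hydroxy in place of fluoro on an aromatic carbon. For the measured compounds named here, no measured pair shows this change, so the expected step in this assay is small, no larger than the scatter, in either direction. The estimate for compound 3 is 16 ug/mL, with a range from 6 ug/mL to 40 ug/mL, meaning an expected step of a 1.2-fold higher number from compound 2 to compound 3 (0.09 log units; within the scatter).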

Compound 3, concentration for half-maximal effect: 30 ug/mL
Estimate against measurement, compound 3: 1.9-fold (0.27 log units) below; measured number inside the range.
By their numbers in this assay, from the lowest: compounds 2, 1 and 3 (each within the scatter of the next, the first and the last beyond it).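

Going from 4-fluorophenyl to 4-hydroxyphenyl in this assay gives a 2.3-fold higher number from compound 2 to compound 3 (0.36 log units; beyond the scatter) and so provides the first measured single-place step in this set. It shows that the number responds, modestly, to the group at this position, with hydroxy needing a larger amount of compound than fluoro for the same effect. Nothing available here gives a reason for this step.

A single step cannot show how other groups behave at this position. A methoxy group, an amine or a carboxylic acid in the same place could move the number either way.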